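A few compounds are considered here, and "the series" means these few. Any claim that something is new, unique, unknown or untested is made for them only; others in the source may bear on it.

For the measured compounds named here, compound 2 `COc1cc(/C=N/n2cnnc2)ccc1O` gives 5940 nM in an assay for inhibition of Alpha amylase (Homo sapiens), with a stated time of 10 min (a higher number here means a weaker inhibitor, a lower number a stronger inhibitor), the highest of the three numbers measured so far. Compound 1 `CCOc1ccc(/C=N/n2cnnc2)cc1OC` gives 5240 nM, and a 1.1-fold higher number from compound 1 to compound 2 (0.05 log units; within the scatter) lies within the scatter. Compound 3 `Oc1ccc(/C=N/n2cnnc2)cc1Br` gives 2270 nM, and a 2.6-fold lower number from compound 2 to compound 3 (0.42 log units; beyond the scatter) counts as a modest gain in potency. Compound 4 `COc1cc(/C=N/n2cnnc2)ccc1F` has not yet been measured; it differs from compound 2 by fluoro in place of hydroxy on an aromatic carbon. Neither measured step makes this exact change. The closer parallel is the step from compound 2 to compound 3, where a halogen replaced an oxygen-bearing group and the number fell modestly, while the change at an oxygen from compound 1 to compound 2 left the number unchanged. A small step is therefore expected, a 1.5-fold lower number from compound 2 to compound 4 (0.17 log units; within the scatter), toward a somewhat lower number at most. Compound 4 is estimated at 4000 nM, within 1500 nM to 10000 nM.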

Compound 4, half-maximal inhibitory concentration: 2330 nM
Compound 4: middle estimate off by 1.7-fold (0.23 log units), on the high side, and the stated range covers the measured number.
By their numbers in this assay, from the lowest: compounds 3 and 4 (each within the scatter of the next); then compounds 1 and 2 (each within the scatter of the next).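

At the carbon para to a group of 7 heavy atoms, the earlier change between ethoxy and hydroxy moved the number only within the scatter, so this place could have seemed indifferent to what sits there. Fluoro shows otherwise, with a 2.5-fold lower number from compound 2 to compound 4 (0.41 log units; beyond the scatter) and a 2.2-fold lower number from compound 1 to compound 4 (0.35 log units; beyond the scatter), so the two oxygen groups read alike while fluoro stands apart. Nothing measured here gives a reason for this. Still open, as far as these compounds go, is whether this belongs to fluoro itself or to any group without oxygen; chloro, an amine or a plain hydrogen at this carbon would separate those.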